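The source may report more compounds than this note shows. Statements on the series, on what has been measured and on what is new or still open speak of the compounds shown alone.

Compound 1 `Nc1nc(Cc2ccccc2)nc2cn(-c3ccccc3O)nc12` is measured in an assay on CHO cells for displacement of a labelled ligand from adenosine receptor A1 (Homo sapiens), read by scintillation counting, with a stated time of 120 min (a higher number here means a weaker inhibitor, a lower number a stronger inhibitor), where compound 1 gives 52 nM. Among the three compounds with numbers, compound 1 stands second highest: its nearest neighbour is compound 3 `Nc1nc(CCCc2ccccc2)nc2cn(-c3ccccc3O)nc12`, which in this assay gives 17 nM, and furthest from it lies compound 2 `Nc1nc(-c2ccco2)nc2cn(Cc3ccccc3O)nc12`, which gives 242 nM. For the measured compounds named here, the one measured step that changes a single place, a 3.1-fold lower number from compound 1 to compound 3 (0.49 log units; beyond the scatter), runs from compound 1 to a longer chain at the same carbon. Compound 4 `Nc1nc(-c2cccs2)nc2cn(-c3ccccc3O)nc12` differs from compound 1 in another way: thiophen-2-yl in place of benzyl on an aromatic carbon. Going by the values given here, no measured pair differs only in this way. Compound 2 carries a five-membered aromatic ring with one hetero atom on the same carbon, but it also differs from compound 1 elsewhere, so its value alone cannot be read as the effect of that ring. Since the step from compound 1 to compound 3 rewards a longer link, a shorter, directly attached ring in compound 4 is expected to give a somewhat higher number, estimated as a 1.7-fold higher number from compound 1 to compound 4 (0.24 log units; within the scatter), though possibly within the scatter. Compound 4 is expected at 90 nM, within 25 nM to 300 nM.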

Compound 4, inhibition constant: 159 nM
Estimate against measurement, compound 4: 1.8-fold (0.25 log units) below; the range from low to high includes it.
By their numbers in this assay, from the lowest: compound 3; then compound 1; then compounds 4 and 2 (each within the scatter of the next).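

In this assay, putting thiophen-2-yl in place of benzyl on this aromatic carbon, between two ring nitrogen atoms, gives a 3.1-fold higher number from compound 1 to compound 4 (0.49 log units; beyond the scatter) and so costs about as much as the longer chain gained in a 3.1-fold lower number from compound 1 to compound 3 (0.49 log units; beyond the scatter). The number at this carbon therefore moves in both directions from compound 1, depending on the group placed there. This change, however, removes the saturated chain carbon and replaces the six-membered ring with a five-membered ring containing sulfur in a single step, so it cannot show which of the two matters. A directly attached phenyl or a thiophen-2-ylmethyl group at this carbon would separate those two changes. Whether a furan-2-yl group behaves like thiophen-2-yl on the core of compound 1 also stays open, and no measurement at hand explains the step.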